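Aryl exchange on the ring nitrogen and adenosine A3 binding

The source may report more compounds than this note shows. Statements on the series, on what has been measured and on what is new or still open speak of the compounds shown alone.

compound 1 `Nc1scc(CN2CCN(c3ccccc3C(F)(F)F)CC2)c1C(=O)c1ccc(Cl)cc1` — 0%
compound 2 `Nc1scc(CN2CCN(c3ccc(C(F)(F)F)cc3)CC2)c1C(=O)c1cccc(C(F)(F)F)c1` — 0%
compound 3 `Nc1scc(CN2CCN(c3cccc(F)c3)CC2)c1C(=O)c1cccc(C(F)(F)F)c1` — 0%

Three compounds sharing the same core were measured in an assay on CHO cells for displacement of a labelled ligand from adenosine receptor A3 (Homo sapiens), read by scintillation counting, with a stated time of 120 min, tested at 10 uM; on this read-out lower numbers stand for less inhibition and higher numbers for more inhibition at the one concentration tested (going by the name of the read-out). Compound 1 gives 0% and stands level with compound 2 and compound 3 at the digits shown; none of the three is separated from another beyond the scatter. Going by the values given here, the single step between measured compounds, no change at the digits printed from compound 2 to compound 3 (within the scatter), shows that exchanging the aryl group on the ring amine nitrogen left the read-out unchanged in that pair.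

Compound 4 `Nc1scc(CN2CCN(c3ccc(F)cc3F)CC2)c1C(=O)c1ccc(Cl)cc1` has not been measured. It differs from compound 1 as follows: 2,4-difluorophenyl in place of 2-(trifluoromethyl)phenyl on an amine nitrogen in a ring. This is the same kind of change as the measured step, an aryl group exchanged on the ring amine nitrogen, and that step produced no movement. The account therefore expects the step from compound 1 to compound 4 to be a number 2 percentage points higher from compound 1 to compound 4 (within the scatter), that is, nothing beyond the scatter. For compound 4 the estimated value in this assay is 2%, with an expected range from -8% to 15%.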

Compound 4, a percentage reported as inhibition, at one concentration (the size of the read-out at that concentration, not a potency): 0%
Compound 4: the middle estimate sits 2 percentage points above what was measured, and the stated range covers the measured number.
By their numbers in this assay, from the lowest: compounds 1, 2, 3 and 4 (each within the scatter of the next).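

In this assay the exchange of 2-(trifluoromethyl)phenyl for 2,4-difluorophenyl on the ring amine nitrogen gives no change at the digits printed from compound 1 to compound 4 (within the scatter). The earlier step, no change at the digits printed from compound 2 to compound 3 (within the scatter), came from a different background, so the same kind of aryl exchange has now been read on the core of compound 1 as well, with the same outcome. Nothing available here explains why the read-out stays at this level.

As far as these compounds go, with all four compounds level, the data do not show whether any group at this position can raise the read-out, so what a pyridine ring or a benzyl group on that nitrogen would give remains open. Also open, from the compounds shown here alone, is whether a change elsewhere, such as an acetamide in place of the free amine on the shared core, would move the read-out at all.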